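The source may hold more compounds than are shown below. What is called first, only, known or untested is meant among the compounds shown, and "the series" means these compounds.

Measured compounds:
- compound 1, `O=C(/C=C/c1ccc(N2CCCCC2)cc1)c1ccsc1`: 32100 nM
- compound 2, `Cc1ccsc1C(=O)/C=C/c1ccc(N2CCCCC2)cc1`: 9900 nM

In an ADME assay on CCRF-CEM cells (Homo sapiens) for cytotoxicity, with a stated time of 5 days (a higher number here means a weaker inhibitor, a lower number a stronger inhibitor), compound 1 gives the highest of the two numbers; its nearest neighbour is compound 2, and the step of a 3.2-fold lower number from compound 1 to compound 2 (0.51 log units; beyond the scatter) lies beyond the scatter. The unmeasured compound 3, `O=C(/C=C/c1ccc(N2CCCCC2)cc1)c1ccc(Br)s1`, differs from compound 1 in one place: 5-bromothiophen-2-yl in place of thiophen-3-yl on a carbonyl carbon. Going by the values given here, no measured step changes the same group in the same way. Among the compounds with values here, the one step that bears on it, a 3.2-fold lower number from compound 1 to compound 2 (0.51 log units; beyond the scatter), also replaces the thiophen-3-yl on the carbonyl carbon with a differently substituted thiophen-2-yl, and it moved the number modestly downward. Within the data shown here, a 5-bromothiophen-2-yl is not a 3-methylthiophen-2-yl, so the transfer is loose, but the direction of that step is the only guide available. A modest decrease, of roughly the size seen from compound 1 to compound 2, is therefore expected, with wide uncertainty. For compound 3 in this assay the estimate is 12000 nM (range 4000 nM to 40000 nM), an expected step of a 2.7-fold lower number from compound 1 to compound 3 (0.43 log units; beyond the scatter).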

Compound 3, half-maximal inhibitory concentration: 52800 nM
The estimate for compound 3 lay 4.4-fold (0.64 log units) below the measured number; measured number above the stated range.
By their numbers in this assay, from the lowest: compound 2; then compounds 1 and 3 (each within the scatter of the next).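

In this assay, the step of a 1.6-fold higher number from compound 1 to compound 3 (0.22 log units; within the scatter) shows that a 5-bromothiophen-2-yl on the carbonyl carbon cannot be told apart from the thiophen-3-yl, so a substituted thiophen-2-yl at this place does not in itself bring the number down. Going by these compounds alone, the step of a 5.3-fold higher number from compound 2 to compound 3 (0.73 log units; beyond the scatter) separates the two substituted thiophen-2-yl groups, which leaves the 3-methylthiophen-2-yl of compound 2 as the only one of the three groups seen here that gives a number lower than the others. No measurement is available that would account for this difference between the methyl-bearing and the bromine-bearing group.

The compounds shown leave open whether the methyl group itself or its place on the thiophene goes with the lower number, a question on which a 3-bromothiophen-2-yl or a 5-methylthiophen-2-yl would bear. They also leave open where an unsubstituted thiophen-2-yl would fall, and how the number would respond to an amine or a carboxylic acid on the thiophene.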